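Working notes: from compound 2 to compound 4

The compounds below may be only part of what the source reports. "The series", "measured", "known", "first", "only" and "open" are said of these compounds alone.

Three compounds of the series have numbers in an assay on CHO cells for displacement of a labelled ligand from 5-hydroxytryptamine receptor 1D (Homo sapiens); a higher number here means a weaker inhibitor, a lower number a stronger inhibitor. Compound 1 `COC[C@H](NC1CCN(CCCc2c[nH]c3ccc(Cn4cncn4)cc23)CC1)c1ccc(F)cc1` gives 5 nM. Compound 2 `C[C@@H](NC1CCN(CCCc2c[nH]c3ccc(-n4cnnc4)cc23)CC1)c1ccccc1` gives 0.4 nM. Compound 3 `OC[C@H](NC1CCN(CCCc2c[nH]c3ccc(-n4ccnc4)cc23)CC1)c1ccccc1` gives 0.7 nM. Compound 2 carries the lowest of the three numbers, but its gap to compound 3 lies within the scatter, so the two cannot be placed in order; only compound 1 sits clearly apart, with a number beyond the scatter above that of compound 2.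

The next compound to be measured is compound 4 `CN(C1CCN(CCCc2c[nH]c3ccc(-n4cnnc4)cc23)CC1)S(=O)(=O)c1ccccc1`. It differs from compound 2 in one place: methyl(phenylsulfonyl)amino in place of (1-phenylethyl)amino on a saturated ring carbon. The hydrogen-bond donor of the amine is gone and a sulfonyl group enters.

No measured pair in the set differs in this way, so the size of the step cannot be read from the numbers shown. The expectation is a move towards a higher number, and a step beyond the scatter; the estimated step is a 50-fold higher number from compound 2 to compound 4 (1.70 log units; beyond the scatter). For compound 4 the expected value in this assay is 20 nM, with a range from 3 nM to 150 nM.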

Compound 4, half-maximal inhibitory concentration: 1.5 nM
Compound 4: the middle estimate sits 13-fold (1.12 log units) above what was measured; the measured number lies below the stated range.
By their numbers in this assay, from the lowest: compounds 2 and 3 (each within the scatter of the next); then compound 4; then compound 1.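

In this assay, methyl(phenylsulfonyl)amino in place of (1-phenylethyl)amino gives a 3.8-fold higher number from compound 2 to compound 4 (0.57 log units; beyond the scatter), a modest step for an exchange that alters so much of the group. This saturated ring carbon therefore accepts a substituent with 0 hydrogen-bond donors, a sulfonyl group and no defined stereocentre, with compound 4 still at 1.5 nM, though this rests on a single pair. Nothing at hand accounts for the size of the step.

The exchange changes several features at once, so the shares of the lost amine hydrogen, the sulfonyl group, the methyl on nitrogen and the lost stereocentre cannot be separated from this one pair. An open question is where a sulfonamide with hydrogen instead of methyl on its nitrogen, or a carboxamide in place of the sulfonamide, would fall relative to compound 2 and compound 4, and whether the step would keep its size on the cores of compound 1 or compound 3.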